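Cyclohexyl in place of 4-fluorophenyl: expecting little change

This account rests on a few compounds, and the source may have more. Where it says the series, first, only, none or still open, it means among the compounds named here.

In a functional assay on HepG2 cells (Homo sapiens) for antiproliferative activity, read by MTT assay, with a stated time of 72 h (on this read-out lower numbers stand for stronger inhibition and higher numbers for weaker inhibition), compound 1 `O=C1COc2ccc(-c3cnc(Cl)c(NS(=O)(=O)c4ccc(F)cc4)c3)cc2N1C1CCCCC1`, with cyclohexyl on the amide-type nitrogen in a ring, gives > 40000 nM, which is a limit of the assay. Compound 2 `COc1cccc(N2C(=O)COc3ccc(-c4cnc(OC)c(NS(=O)(=O)c5ccc(F)cc5)c4)cc32)c1` gives > 40000 nM, also a limit. Going by the values given here, compound 3 `COc1ncc(-c2ccc3c(c2)N(c2ccc(F)cc2)C(=O)CO3)cc1NS(=O)(=O)c1ccc(F)cc1` gives 36400 nM, the only actual number of the three. Compound 4 `COc1ncc(-c2ccc3c(c2)N(C2CCCCC2)C(=O)CO3)cc1NS(=O)(=O)c1ccc(F)cc1` differs from compound 3 by cyclohexyl in place of 4-fluorophenyl on that nitrogen: cyclohexyl in place of 4-fluorophenyl on an amide-type nitrogen in a ring. Among the compounds with values here, the one measured step on this nitrogen is an at least 1.0-fold lower number from compound 2 to compound 3 (0.04 log units; that floor lies within the scatter). The series otherwise offers (the limit of > 40000 nM in this assay, at which 2 of the 3 values shown sit). The estimated change is a 1.1-fold higher number from compound 3 to compound 4 (0.04 log units; within the scatter), so no step beyond the scatter is expected in this assay. Compound 4 is estimated at 40000 nM, with an expected range of 15000 nM to 100000 nM.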

Compound 4, half-maximal inhibitory concentration: > 40000 nM
Compound 4 was reported as a limit; the forecaster's own chance of this, stated with the estimate: 60%; the middle value sits exactly at the limit.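

Cyclohexyl in place of 4-fluorophenyl on the amide-type nitrogen, with methoxy kept on the shared core, gives an at least 1.0-fold higher number from compound 3 to compound 4 (0.04 log units; that floor lies within the scatter) in this assay; only this floor can be read, because the value of compound 4 is a limit. The steps to compound 4 from compound 1 and from compound 2 cannot be read. The series now gathers further at one value: the limit of > 40000 nM in this assay, at which 3 of the 4 values shown sit.

From the compounds shown here alone, it remains open whether a chain ending in an amine or a carboxylic acid on this nitrogen would give a readable number, and how far compound 4 truly lies from compound 3.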